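Replacing 2-fluorophenyl with methyl on a weak inhibitor

A few compounds are considered here, and "the series" means these few. Any claim that something is new, unique, unknown or untested is made for them only; others in the source may bear on it.

Of the compounds shown here, three sharing one core have been measured in a functional assay on V79-379A cells (Cricetulus griseus) for cytotoxicity, read by MTT assay, in the presence of a further agent that is not named here; a higher number here means a weaker inhibitor, a lower number a stronger inhibitor. There, compound 1 `COC1=CC(=O)c2c(c(CCl)cn2C)C1=O` gives 304000 nM, and compound 2 `COC1=CC(=O)c2c(c(COC(=O)c3ccccc3F)cn2C)C1=O` gives 500 nM. For the measured compounds named here, compound 3 `COC1=CC(=O)c2c(c(COC(=O)c3ccccc3F)c(C)n2C)C1=O` gives 164000 nM, a number within the usual scatter of the one for compound 1 and far higher than the one for compound 2.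

Going by the values given here, only one change at a single place has been measured so far. It is a methyl in place of hydrogen on an aromatic carbon, and it produced a 330-fold higher number from compound 2 to compound 3 (2.52 log units; beyond the scatter).

The next compound, compound 4 `COC1=CC(=O)c2c(c(COC(C)=O)c(C)n2C)C1=O`, keeps that methyl but differs elsewhere: methyl in place of 2-fluorophenyl on a carbonyl carbon. This is a methyl in place of 2-fluorophenyl on a carbonyl carbon, a place where no change has yet been measured. The large step above therefore shows how much this series can move, but it gives no direction for the new change. The starting point is compound 3 at 164000 nM, which already carries the same ring methyl as compound 4. No step beyond the scatter is expected in this assay, and the estimate is a 1.4-fold lower number from compound 3 to compound 4 (0.14 log units; within the scatter). For compound 4, the estimated value is 120000 nM, with an expected range from 25000 nM to 450000 nM.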

Compound 4, half-maximal inhibitory concentration: 27000 nM
Beside the measured number, compound 4's estimate is 4.4-fold (0.65 log units) above it; low and high end bracket the measured number.
By their numbers in this assay, from the lowest: compound 2; then compound 4; then compounds 3 and 1 (each within the scatter of the next).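

In this assay, the carbonyl carbon proves to be a place where the number can move even when the aromatic carbon carries a methyl: methyl in place of 2-fluorophenyl gives a 6.1-fold lower number from compound 3 to compound 4 (0.78 log units; beyond the scatter), a step beyond the usual scatter. For the compounds shown here, this is the first measured change at this place, and it shows that the six-membered aromatic ring of 2-fluorophenyl is not needed here, as the smaller methyl gives the stronger inhibitor of this pair. The step is still modest beside the large 330-fold higher number from compound 2 to compound 3 (2.52 log units; beyond the scatter), and nothing shown here explains why swapping these two groups lowers the number.

From the compounds shown here alone, it remains open whether the same swap would lower the number by a similar amount on compound 2, which has hydrogen rather than methyl on the aromatic carbon, or whether the two changes depend on each other. Going by these compounds, it is also open how far this trend runs on the carbonyl carbon: a longer chain such as propyl, an unsubstituted phenyl or an amine there could tell whether size or some other feature of the group tracks with the number.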